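Swapping a Saturated Ring for an Aromatic One

The source may hold more compounds than are shown below. What is called first, only, known or untested is meant among the compounds shown, and "the series" means these compounds.

Of the compounds shown here, two have been tested in an assay on isolated protein for binding affinity to Equilibrative nucleoside transporter 1 (Homo sapiens); on this read-out lower numbers stand for stronger inhibition and higher numbers for weaker inhibition. Compound 1, `O=[N+]([O-])c1cccc2c1CCN(c1ncnc3c1nc1n3[C@@H]3O[C@H](CO1)[C@@H](O)[C@H]3O)C2`, gives 7410000 nM in this assay, a very high number that marks it as a weak inhibitor. Compound 2, `OC[C@H]1O[C@@H](n2cnc3c(SCC4CCCCC4)ncnc32)[C@H](O)[C@@H]1O`, gives 1550 nM in this assay, the lower of the two numbers, and the gap to compound 1 is far beyond the usual scatter of repeat measurements.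

Compound 3, `Cc1ccc(CSc2ncnc3c2ncn3[C@@H]2O[C@H](CO)[C@@H](O)[C@H]2O)cc1`, has not yet been measured. It differs from compound 2 in one place: 4-methylphenyl in place of cyclohexyl on a saturated chain carbon bound to a sulfur. The sugar, the shared core and the sulfur-bearing chain are untouched; only the ring at the end of that chain changes from a saturated one to an aromatic one of nearly the same size.

Within the data shown here, no pair of measured compounds shows this kind of change, so its effect can only be guessed. The expectation is a small step, with the number for compound 3 staying close to or somewhat below that of compound 2, the estimated step being a 1.9-fold lower number from compound 2 to compound 3 (0.29 log units; within the scatter). Compound 3 is therefore expected to give about 800 nM in this assay, with a plausible range from 200 nM to 4000 nM.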

Compound 3, half-maximal inhibitory concentration: 457 nM
Compound 3: middle estimate off by 1.8-fold (0.24 log units), on the high side; the range from low to high includes it.
By their numbers in this assay, from the lowest: compound 3; then compound 2; then compound 1.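

In this assay the change gives a 3.4-fold lower number from compound 2 to compound 3 (0.53 log units; beyond the scatter) and so shows that this position responds to what sits at the end of the sulfur-bearing chain, even with the sugar and the shared core held constant. Among these compounds, this is the first comparison here between compounds that differ in one place, and it shows that 4-methylphenyl is accepted on the saturated chain carbon bound to the sulfur and gives a lower number than cyclohexyl, although the step is only modest. No further measurement here bears on why the number falls.

The swap replaces a saturated ring with an aromatic one and brings in a methyl group at the same time, so these compounds cannot show how much of the step belongs to each, and a plain benzyl group on the sulfur would help to separate the two. From the compounds shown here alone, it also remains open how the number would respond to a chlorine atom or a methoxy group in place of that methyl, or to a longer chain on the sulfur.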